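Thiocarbamoyl substitution on the ring nitrogen of compound 1

The source may report more compounds than this note shows. Statements on the series, on what has been measured and on what is new or still open speak of the compounds shown alone.

Compound 1 `Cn1cccc1-c1cc(-c2ccc(Br)cc2)[nH]c(=O)c1C#N`: in a functional assay on HCC 2998 cells (Homo sapiens) for cytotoxicity, read by sulforhodamine B assay, with a stated time of 48 h (on this read-out lower numbers stand for stronger inhibition of growth and higher numbers for weaker inhibition of growth), compound 1 gives > 100000 nM, a limit of the assay.
Compound 2 `COc1ccc(-c2cc(-c3cccn3C)c(C#N)c(=O)[nH]2)cc1OC`: in this assay compound 2 gives 89100 nM.
Compound 3 `COc1ccc(-c2cc(-c3cccs3)[nH]c(=O)c2C#N)cc1`: in this assay compound 3 gives > 100000 nM, a limit of the assay.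

Going by the values given here, compound 1 sits at the limit of > 100000 nM in this assay, at which 2 of the 3 values shown sit, so only a limit is known for it, and no step between two measured compounds can be drawn from these three. Compound 4 `Cn1cccc1-c1cc(-c2ccc(Br)cc2)n(C(=S)Nc2ccc(F)cc2)c(=O)c1C#N` differs from compound 1 by a group of 10 heavy atoms (7 carbon, 1 nitrogen, 1 fluorine, 1 sulfur; one six-membered aromatic ring of carbon only) in place of a hydrogen atom, on an aromatic nitrogen. Among the compounds with values here, nothing among the measured compounds shows what such a change does, so the expectation rests on the shared core alone and stays cautious. The step of an at least 2.0-fold lower number from compound 1 to compound 4 (0.30 log units; that floor lies within the scatter) is expected, a gain beyond the scatter but not a large one, with a real chance that only a limit is reported again. Compound 4 is estimated at 50000 nM, with a range from 12000 nM to 150000 nM.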

Compound 4, concentration for 50% growth inhibition: > 100000 nM
Compound 4 ended at the assay's limit; the forecaster's own chance of this, stated with the estimate: 40%; middle value at least 2.0-fold (0.30 log units) from the limit.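

Going by these compounds alone, compound 1 and compound 4 both end at a limit of the assay, not at a number, so no step between them can be read: the limit of > 100000 nM in this assay, at which 3 of the 4 values shown sit.

The compounds shown leave open whether the added group on the aromatic nitrogen changes growth inhibition at all.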